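A few compounds are considered here, and "the series" means these few. Any claim that something is new, unique, unknown or untested is made for them only; others in the source may bear on it.

Working notes on the series. Compound 3 `COc1cc(N)c(Cl)cc1C(=O)CCC1CCN(CCNS(=O)(=O)c2ccc(NC(C)=O)cc2)CC1` stands highest of the three measured numbers: in an assay on HEK293 cells for displacement of a labelled ligand from 5-hydroxytryptamine receptor 6 (Homo sapiens), with a stated time of 60 min, tested at 1 uM, in the presence of a further agent that is not named here (a lower number here means a weaker effect, a higher number a stronger effect of the compound at the concentration tested), compound 3 gives 67%. Compound 1 `COc1cc(N)c(Cl)cc1C(=O)CCC1CCN(CCNS(=O)(=O)c2ccc3c(c2)NC(=O)CO3)CC1` gives 40% in this assay, and compound 2 `COc1cc(N)c(Cl)cc1C(=O)CCC1CCN(CCNS(=O)(=O)c2ccc(C)cc2)CC1` gives 15%. All three differ only in the group on the sulfonyl sulfur. The steps are a number 27 percentage points higher from compound 1 to compound 3 (beyond the scatter) and a number 25 percentage points lower from compound 1 to compound 2 (beyond the scatter), and the direct comparison of the two phenyl analogues is a number 52 percentage points higher from compound 2 to compound 3 (beyond the scatter), which is the largest movement seen here.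

Compound 4 `COc1cc(N)c(Cl)cc1C(=O)CCC1CCN(CCNS(=O)(=O)c2cc(Br)c(N)c(Br)c2)CC1` is not yet measured. Relative to compound 3 the change is 4-amino-3,5-dibromophenyl in place of 4-acetamidophenyl on a sulfonyl sulfur. Going by the values given here, no measured step covers an amino or a bromine on this ring, so the only bearing steps are those that alter the group on the sulfonyl sulfur. The large step from methyl to acetamido shows that the group at this position moves the read-out strongly, and compound 4 no longer carries the acetamido that accompanied the highest number. A drop beyond the scatter is therefore expected, of modest size rather than a return to the level of compound 2, since the entering group keeps one donor and one acceptor. Compound 4 is expected to give 45%, in the range 20% to 70%. The expected step is a number 22 percentage points lower from compound 3 to compound 4 (beyond the scatter).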

Compound 4, a percentage reported as inhibition, at one concentration (the size of the read-out at that concentration, not a potency): 83%
The estimate for compound 4 lay 38 percentage points below the measured number, outside the stated range (above it).
By their numbers in this assay, from the lowest: compound 2; then compound 1; then compound 3; then compound 4.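

The acetamido group is not needed for a high read-out at this position: in this assay, 4-amino-3,5-dibromophenyl on the sulfonyl sulfur gives a number 16 percentage points higher from compound 3 to compound 4 (beyond the scatter), so compound 4 stands highest of the four, and a group with no carbonyl outside the ring can exceed the one that led the series. The same entering group also gives a number 68 percentage points higher from compound 2 to compound 4 (beyond the scatter) and a number 43 percentage points higher from compound 1 to compound 4 (beyond the scatter), which widens the span of read-outs produced by changing this one group, while the shared core stays the same. No measurement given here bears on the reason for this rise, so it remains an observation without an explanation.

The amino group and the two bromines enter together in compound 4, so the contribution of each cannot be separated, and a plain 4-aminophenyl or a 4-amino-3,5-dichlorophenyl group on the sulfonyl sulfur would be needed to divide the step between them. These are also read-outs at a single concentration, so they show only a stronger or weaker effect at that concentration and leave open whether the order of the four compounds would hold at other concentrations.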